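A few compounds are considered here, and "the series" means these few. Any claim that something is new, unique, unknown or untested is made for them only; others in the source may bear on it.

In an ADME assay on RAW264.7 cells (Mus musculus) for cytotoxicity, read by MTT assay, with a stated time of 18 h (a higher number here means that more compound is tolerated, a lower number that less compound is tolerated), compound 1 `C=C1C(=O)OC[C@H]1CCOC(=O)Nc1ccc(Cl)cc1` gives 9140 nM. Compound 2 `C=C1C(=O)OC[C@H]1CCOC(=O)Nc1ccc(Br)cc1` gives 8470 nM in this assay, and compound 3 `C=C1C(=O)OC[C@@H]1CCOC(=O)Nc1ccc(Br)cc1` gives 19800 nM. Of these three numbers, compound 2 carries the lowest; compound 1 sits nearest to it, while compound 3 lies furthest away. The step of a 1.1-fold lower number from compound 1 to compound 2 (0.03 log units; within the scatter) shows that exchanging one halogen for another on the aromatic ring left the number where it was. The step of a 2.3-fold higher number from compound 2 to compound 3 (0.37 log units; beyond the scatter) is larger and goes together with the fact that compounds 2 and 3 differ only in the configuration as drawn.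

Compound 4 `C=C1C(=O)OC[C@H]1CCOC(=O)Nc1ccc(C(C)C)cc1` has not yet been measured in this assay. Relative to compound 2 the change is isopropyl in place of bromo on an aromatic carbon. Of the two measured steps, only the halogen exchange between compound 1 and compound 2 touches the same place on the aromatic ring, and that step stayed within the scatter; the configurational step between compound 2 and compound 3 concerns a different part of the molecule and says nothing about a substituent swap. On that basis a step of a 1.1-fold higher number from compound 2 to compound 4 (0.03 log units; within the scatter) is expected, that is, none beyond the scatter, though the new group is a carbon chain rather than a halogen and the evidence is thin. Compound 4 is therefore estimated at 9000 nM, with a range from 4000 nM to 20000 nM.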

Compound 4, half-maximal cytotoxic concentration: 12400 nM
Compound 4: the middle estimate sits 1.4-fold (0.14 log units) below what was measured; low and high end bracket the measured number.
By their numbers in this assay, from the lowest: compounds 2, 1, 4 and 3 (each within the scatter of the next, the first and the last beyond it).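

In this assay, the position on the aromatic carbon, para to a large group, has now taken a carbon group as well as two halogens, and neither new step leaves the scatter: the exchange of bromo for isopropyl gives a 1.5-fold higher number from compound 2 to compound 4 (0.17 log units; within the scatter) and the exchange of chloro for isopropyl gives a 1.4-fold higher number from compound 1 to compound 4 (0.13 log units; within the scatter). Going by these compounds alone, until now this place had only seen one halogen swapped for another, so the earlier compounds could not show that a group of a different element and with more heavy atoms than bromo or chloro would also leave the number within the scatter of both halogen compounds. Nothing in the information available explains this result at this position.

The compounds shown carry only chloro, bromo or isopropyl here, so it remains open whether an amine, a carboxylic acid or a longer chain at this place would move the number beyond the scatter. As far as these compounds go, the opposite drawn configuration appears only with bromo, so it also remains open whether the configurational step seen there would recur with isopropyl in place of bromo.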